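Fluoro for chloro on a pyridyl-bearing triazolothiadiazole

A few compounds are considered here, and "the series" means these few. Any claim that something is new, unique, unknown or untested is made for them only; others in the source may bear on it.

Of the compounds shown here, three sharing one core have been measured in a functional assay on the whole organism (strain Wistar Albino) for inhibition, with Rattus norvegicus as the target, read by paw edema, with a stated time of 3 h, at a dose of 20 mg/kg; a lower number here means less inhibition, a higher number more inhibition at the dose given (going by the name of the read-out). Compound 1 `Cc1occc1-c1nnc2sc(-c3ccnc4ccccc34)nn12` gives 20.3%, compound 2 `Cc1occc1-c1nnc2sc(-c3cc(O)nc(O)c3)nn12` gives 16.5%, and compound 3 `COc1ccc(Cc2nnc3sc(-c4ccnc(Cl)c4)nn23)cc1OC` gives 22.5%. Compound 3 carries the numerically largest read-out of the three, yet its gaps to compound 1 and to compound 2 both lie within the scatter of repeated measurements, so the three numbers cannot be told apart on this evidence.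

Compound 4 `COc1ccc(Cc2nnc3sc(-c4ccnc(F)c4)nn23)cc1OC` has not yet been measured. It differs from compound 3 in one place: fluoro in place of chloro on an aromatic carbon. Going by the values given here, no pair of measured compounds differs by a single change, so no measured step guides the expectation directly. A swap of one halogen for another at the same aromatic carbon is small, and the expectation is a step from compound 3 to compound 4 of no size beyond the scatter in this assay, a number 1.5 percentage points lower from compound 3 to compound 4 (within the scatter). Compound 4 is therefore estimated at 21%, within a range from 11% to 31%.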

Compound 4, a percentage reported as inhibition, in the whole organism at one dose (the size of the read-out at that dose, not a potency): 16.7%
Estimate against measurement, compound 4: 4.3 percentage points above; measured number inside the range.
By their numbers in this assay, from the lowest: compounds 2, 4, 1 and 3 (each within the scatter of the next).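

In this assay, going by these compounds alone, the change from 2-chloropyridin-4-yl to 2-fluoropyridin-4-yl gives the first step that can be read in one place, a number 5.8 percentage points lower from compound 3 to compound 4 (within the scatter) at this dose. Within the data shown here, at this aromatic carbon next to the ring nitrogen, fluoro and chloro therefore cannot be told apart on this read-out, which the earlier compounds, differing in more than one place, could not show. Nothing measured alongside these compounds bears on what lies behind this step.

From the compounds shown here alone, it remains open whether a group other than a halogen on this carbon, such as an amine, a nitrile or a carboxylic acid, would give a step beyond the scatter. Going by these compounds, it is equally open whether the same swap of fluoro for chloro would read alike with the rest of the molecule changed.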